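The source may report more compounds than this note shows. Statements on the series, on what has been measured and on what is new or still open speak of the compounds shown alone.

In an ADME assay on HepG2 cells (Homo sapiens) for cytotoxicity, read by luminescence, with a stated time of 72 h (a higher number here means that more compound is needed for the effect, a lower number that less compound is needed), compound 1 (`CCOC(=O)c1c(-c2cccc(C)c2)[nH]c2cc(OC)ccc2c1=O`) gives > 21500 nM as a limit of the assay and not a number. Compound 2 (`CCOC(=O)c1c(-c2cccc(S(C)(=O)=O)c2)[nH]c2cc(OC)ccc2c1=O`) gives > 21500 nM as a limit too, so it has no readable numerical position in the series. The next compound is compound 3 (`CCOC(=O)c1c(-c2cccc(CO)c2)[nH]c2cc(OC)ccc2c1=O`), which carries hydroxymethyl in place of methylsulfonyl on an aromatic carbon, meta to a large group. The counted difference is hydroxymethyl in place of methylsulfonyl on an aromatic carbon and the core stays the same. Within the data shown here, the one measured step involving the departing group is a step that the two limits leave unreadable from compound 1 to compound 2 with methylsulfonyl in place of methyl on an aromatic carbon, and it supplies no size to carry over. The series offers only the limit of > 21500 nM in this assay, at which 2 of the 2 values shown sit, as a guide for compound 3, so no step beyond the scatter is expected in this assay and no direction is assigned. The estimated change is a step that the limit leaves unreadable from compound 2 to compound 3 and remains an expectation only. For compound 3 the expected value is 25000 nM with an estimated range from 12000 nM to 50000 nM and a further limit is the most likely report.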

Compound 3, half-maximal effective concentration: > 21500 nM
Compound 3 gave a limit, no number; the forecaster's own chance of this, stated with the estimate: 85%; the middle value does not contradict the limit.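

In this assay compound 3 gives > 21500 nM, a limit of the assay and not a number. Among these compounds, with compound 1 and compound 2 also reported only as limits, no step among compound 1, compound 2 and compound 3 can be read. The compounds shown leave open whether methyl, methylsulfonyl and hydroxymethyl differ at all in this assay.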